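Hydroxy to methoxy: from compound 1 to compound 4

The source may report more compounds than this note shows. Statements on the series, on what has been measured and on what is new or still open speak of the compounds shown alone.

Compound 1 `O=C(Nc1ccc(O)c(-c2nc3ccccc3s2)c1)c1cc([N+](=O)[O-])ccc1Cl` gives > 25000 nM in an ADME assay on HepG2 cells (Homo sapiens) for cytotoxicity, with a stated time of 72 h (on this read-out higher numbers stand for an effect only at larger amounts of compound and lower numbers for an effect already at smaller amounts), as its reading, and this is a limit and not a number. Compound 2 `O=C(Nc1nc2ccc(F)cc2s1)c1cc([N+](=O)[O-])ccc1Cl` gives > 27000 nM in this assay as its reading, again a limit. Compound 3 `Cc1cc(NC(=O)c2cc([N+](=O)[O-])ccc2Cl)cc(-c2nc3ccccc3s2)c1O` gives > 25000 nM in this assay as its reading, likewise a limit. Among the measured compounds shown here, the series so far stands at the limit of > 25000 nM in this assay, at which 2 of the 3 values shown sit, and at the limit of > 27000 nM in this assay, at which 1 of the 3 values shown sits, and holds no numeric value.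

Compound 4 `COc1ccc(NC(=O)c2cc([N+](=O)[O-])ccc2Cl)cc1-c1nc2ccccc2s1` differs from compound 1 by methyl in place of hydrogen on an oxygen on an aromatic ring as the counted change, which reads as hydroxy to methoxy, methyl in place of hydrogen on an oxygen on an aromatic ring. For the measured compounds named here, the one measured step in which a methyl enters is a step that the two limits leave unreadable from compound 1 to compound 3 and it places the methyl on an aromatic carbon, not on the oxygen. Going by the values given here, its size cannot be read, so it gives only weak guidance, and no measured step covers the oxygen itself.

No shift beyond the scatter is expected in this assay and a further limit is the likeliest reading. The expected step is a step that the limit leaves unreadable from compound 1 to compound 4 as an estimate. For compound 4 the estimated value is 28000 nM with an expected range from 12000 nM to 60000 nM around it.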

Compound 4, half-maximal effective concentration: > 25000 nM
Compound 4: a limit, no number (the forecaster's own chance of this, stated with the estimate: 80%); the middle value lies beyond the limit too.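

Among the compounds shown here, compound 1 and compound 4 both stand at a limit and not at a number in this assay, so the step from hydroxy to methoxy cannot be read and no new step follows. The compounds shown leave open whether any change to the core of compound 1 would give a numeric reading in this assay.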